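Chloro for Trifluoromethyl: Expecting Another Cytotoxicity Limit

This account rests on a few compounds, and the source may have more. Where it says the series, first, only, none or still open, it means among the compounds named here.

Compound 2 `COc1ccccc1NC(=O)COc1cc(C)nc2ccc(C(F)(F)F)cc12` was tested in an ADME assay on HepG2 cells (Homo sapiens) for cytotoxicity, read by trypan blue exclusion, with a stated time of 48 h, in the presence of a further agent that is not named here; on this read-out lower numbers stand for higher toxicity in this test and higher numbers for lower toxicity in this test. In this assay compound 2 gives only a limit, > 128000 nM. Compound 1 `COc1ccc2nc(C)cc(OCC(=O)Nc3ccccc3)c2c1` likewise returns a limit, > 155000 nM. Compound 3 `CCCCCNC(=O)COc1cc(C)nc2ccc(OC)cc12` also returns a limit, > 158000 nM. The single one-point step among these, a step that the two limits leave unreadable from compound 1 to compound 3, cannot be sized because both of its values sit at limits the limit of > 155000 nM in this assay, at which 1 of the 3 values shown sits, and (the limit of > 158000 nM in this assay, at which 1 of the 3 values shown sits); compound 2 sits at a limit as well (the limit of > 128000 nM in this assay, at which 1 of the 3 values shown sits).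

Compound 4 `COc1ccccc1NC(=O)COc1cc(C)nc2ccc(Cl)cc12` differs from compound 2 by chloro in place of trifluoromethyl on an aromatic carbon. Within the data shown here, no measured step touches this change, and the only known step is unreadable. Compound 4 is therefore expected to remain at a limit, with an estimated value of 150000 nM and a range from 60000 nM to 400000 nM. This estimate implies an expected step that the limit leaves unreadable from compound 2 to compound 4, within the scatter.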

Compound 4, half-maximal cytotoxic concentration: 140000 nM
Compound 4: the middle estimate sits 1.1-fold (0.03 log units) above what was measured, and the stated range covers the measured number.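

Among these compounds, compound 2 gives only a limit, > 128000 nM, so no step from compound 2 to compound 4 can be read. The compounds shown leave open whether chloro in place of trifluoromethyl on an aromatic carbon shifts the read-out at all.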